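Notes on compound 4: 4-iodophenyl to 2-nitrophenyl

This account rests on a few compounds, and the source may have more. Where it says the series, first, only, none or still open, it means among the compounds named here.

Compound 1 `O=C(Nc1ccc(I)cc1)Nc1nc(-c2cc3ccccc3o2)cs1` gives 62000 nM in a physicochemical assay, with a stated time of 6 min (a higher number here means a weaker inhibitor, a lower number a stronger inhibitor), and stands lowest of the two numbers shown; compound 3 `O=C(Nc1ccc(I)cc1)Nc1nc(-c2cc3cc([N+](=O)[O-])ccc3o2)cs1` is nearest with 62400 nM. The step of a 1.0-fold higher number from compound 1 to compound 3 (0.00 log units; within the scatter) is the only one measured in this series, and it leaves the number unchanged. Compound 2 `Cc1ccc(NC(=O)Nc2nc(-c3cc4cc(Br)ccc4o3)cs2)cc1` reaches only the limit of > 200000 nM in this assay; its value is a limit, as recorded in the limit of > 200000 nM in this assay, at which 1 of the 3 values shown sits.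

Compound 4 `O=C(Nc1nc(-c2cc3ccccc3o2)cs1)Nc1ccccc1[N+](=O)[O-]` carries the change (2-nitrophenyl in place of 4-iodophenyl on an amide-type nitrogen). For the measured compounds named here, no measured step touches the amide-type nitrogen whose other neighbour is the carbonyl carbon, so the direction of this change has no direct precedent here; the one measured step, a 1.0-fold higher number from compound 1 to compound 3 (0.00 log units; within the scatter), shows a nitro on another ring to be neutral. The whole set sits at weak numbers, with compound 2 only a limit, so a large gain is not expected. The estimate for compound 4 is 100000 nM, within 30000 nM to 300000 nM, which would mean an expected step of a 1.6-fold higher number from compound 1 to compound 4 (0.21 log units; within the scatter).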

Compound 4, half-maximal inhibitory concentration: 20300 nM
The estimate for compound 4 lay 4.9-fold (0.69 log units) above the measured number; measured number below the stated range.
By their numbers in this assay, from the lowest: compound 4; then compounds 1 and 3 (each within the scatter of the next). At a limit, above all of these: compound 2.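

In this assay, for the compounds shown here, the aryl group on the amide-type nitrogen whose other neighbour is the carbonyl carbon can move the number, whereas the only earlier step, a 1.0-fold higher number from compound 1 to compound 3 (0.00 log units; within the scatter), placed a nitro on an aromatic carbon elsewhere and left the number within the scatter. Putting 2-nitrophenyl in place of 4-iodophenyl gives a 3.1-fold lower number from compound 1 to compound 4 (0.48 log units; beyond the scatter), a modest gain beyond the scatter, so this is the first place in the series shown to respond to change. Nothing shown here bears on why this step occurs.

This single step changes both the substituent and where it sits on the phenyl ring, so the two contributions cannot be separated. As far as these compounds go, whether an amine or a carboxylic acid on this ring would follow compound 4 or compound 1 remains open.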